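Chloro in place of hydrogen: compound 2 to compound 3

The source may report more compounds than this note shows. Statements on the series, on what has been measured and on what is new or still open speak of the compounds shown alone.

Measured in an ADME assay on NIH3T3 cells (Mus musculus) for inhibition, read by CCK-8 assay, with a stated time of 48 h; on this read-out higher numbers stand for weaker inhibition and lower numbers for stronger inhibition:
- compound 1 `C#CCOc1ccc(C(=O)/C=C/c2ccc(Cl)c(Cl)c2)cc1`: 61800 nM
- compound 2 `C#CCOc1ccc(C(=O)/C=C/c2cccc(Cl)c2)c(O)c1`: 79500 nM

In this assay compound 2 gives 79500 nM, within the usual scatter of compound 1. Compound 3 `C#CCOc1ccc(C(=O)/C=C/c2ccc(Cl)c(Cl)c2)c(O)c1` has chloro in place of hydrogen on an aromatic carbon, ortho to a chloro group and para to a large group (chloro in place of hydrogen on an aromatic carbon). For the measured compounds named here, no measured pair isolates this change. Going by the values given here, the only guide is compound 1 at 61800 nM, which has the same chloro substitution as compound 3 on a different core. No step beyond the scatter is expected in this assay, and no direction is favoured. The expected size is a 1.2-fold lower number from compound 2 to compound 3 (0.09 log units; within the scatter). Compound 3 is estimated at 65000 nM, with an expected range of 30000 nM to 130000 nM.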

Compound 3, half-maximal inhibitory concentration: 94700 nM
Estimate against measurement, compound 3: 1.5-fold (0.16 log units) below; measured number inside the range.
By their numbers in this assay, from the lowest: compounds 1, 2 and 3 (each within the scatter of the next).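

In this assay chloro in place of hydrogen on an aromatic carbon, ortho to a chloro group, gives a 1.2-fold higher number from compound 2 to compound 3 (0.08 log units; within the scatter), the first measured pair isolating this change. The added hydroxy group gives a 1.5-fold higher number from compound 1 to compound 3 (0.19 log units; within the scatter), so neither single change separates its pair in this read-out. No available evidence bears on these results.

Going by these compounds, whether an amine or a carboxylic acid at the chloro position would give a step beyond the scatter remains open. So does the effect of either change in any other assay.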